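Swapping Cyano for Methyl on the Pyrazole Ring

A few compounds are considered here, and "the series" means these few. Any claim that something is new, unique, unknown or untested is made for them only; others in the source may bear on it.

Of the compounds shown here, two have so far been measured in a physicochemical assay for lipophilicity, using the shake flask method, at pH 7.4; on this read-out lower numbers stand for lower lipophilicity and higher numbers for higher lipophilicity. Compound 1 `O=C(O)CCNC(=O)c1ccc(C(Oc2ccc(-n3cc(C(F)(F)F)cn3)cc2)C2CC2)cc1` gives 1.7 in this assay. Compound 2 `CCCC(Oc1ccc(-n2cc(C#N)cn2)cc1)c1ccc(C(=O)NCCC(=O)O)cc1` gives 1.2, the lower of the two numbers, sitting a step below compound 1 that goes beyond the scatter. Compound 1 and compound 2 differ in more than one place, so the two values are simply set side by side without a single change to tie them together.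

Compound 3 `CCCC(Oc1ccc(-n2cc(C)cn2)cc1)c1ccc(C(=O)NCCC(=O)O)cc1` has not yet been measured. It differs from compound 2 in one place: methyl in place of cyano on an aromatic carbon. Among the compounds with values here, no measured pair shows this particular swap, so the expectation rests on the structures alone. An upward step a number 0.70 log units higher from compound 2 to compound 3 (beyond the scatter) is expected, going beyond the scatter. For compound 3 the estimate in this assay is 1.9, with a range from 1.5 to 2.3.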

Compound 3, distribution coefficient: 2.1
Beside the measured number, compound 3's estimate is 0.20 log units below it, and the stated range covers the measured number.
By their numbers in this assay, from the lowest: compound 2; then compound 1; then compound 3.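

Within this assay, the change from 4-cyano-1H-pyrazol-1-yl to 4-methyl-1H-pyrazol-1-yl gives the first comparison in which only one place differs, with a number 0.90 log units higher from compound 2 to compound 3 (beyond the scatter). This shows that the group on this aromatic carbon, two ring bonds from the ring nitrogen, can move the number clearly on its own, something compound 1 and compound 2 could not show, as they differ in more than one place. Nothing measured here explains the size or direction of this step.

This single pair leaves open whether the same swap would give a similar step on a different core, such as the core of compound 1. It also leaves open where other groups on this carbon, such as a methoxy group, a chlorine atom or an amine, would fall.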